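Methylation of the phenol in the urea series

The compounds below may be only part of what the source reports. "The series", "measured", "known", "first", "only" and "open" are said of these compounds alone.

Measured so far in a functional assay on HCC 2998 cells (Homo sapiens) for inhibition, read by sulforhodamine B assay, with a stated time of 48 h, tested at 10 uM; on this read-out higher numbers stand for a weaker effect at the one concentration tested and lower numbers for a stronger effect:
compound 1 `COc1cc(Cl)cc(-c2nn(-c3cccc(NC(=O)c4ccc(Cl)c(Cl)c4)c3)cc2-c2ccncc2)c1` gives 77.8%
compound 2 `O=C(Nc1cccc(-n2cc(-c3ccncc3)c(-c3cc(O)cc(Cl)c3)n2)c1)Nc1ccc(Cl)c(C(F)(F)F)c1` gives 34.3%
compound 3 `O=C(Nc1cccc(-n2cc(-c3ccncc3)c(-c3cc(O)cc(Cl)c3)n2)c1)Nc1ccc(Cl)c(Cl)c1` gives 0.57%

Compound 2 sits second highest of the three numbers. Its nearest neighbour is compound 3, reached by a number 33.7 percentage points lower from compound 2 to compound 3 (beyond the scatter), a large step from a single change: chloro in place of trifluoromethyl on an aromatic carbon. Going by the values given here, compound 1 stands furthest away, higher than compound 2 by a margin beyond the scatter, but compound 1 and compound 2 differ in two places at once, so no single step connects them.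

The compound under consideration is compound 4 `COc1cc(Cl)cc(-c2nn(-c3cccc(NC(=O)Nc4ccc(Cl)c(C(F)(F)F)c4)c3)cc2-c2ccncc2)c1`. It differs from compound 2 by methyl in place of hydrogen on an oxygen on an aromatic ring.

Among the compounds with values here, no measured step bears on this change. Within the data shown here, the one step known, from compound 2 to compound 3, concerns the other aryl group, and compound 1 carries the methoxy group but also an amide in place of the urea, so its number cannot be read as the effect of methylation alone. Among the measured compounds shown here, the only guidance is that compound 1, the methoxy-bearing compound, gives the highest number of the three.

Compound 4 is therefore expected to give 50%, with a range from 25% to 80%. This estimate means a step of a number 15.7 percentage points higher from compound 2 to compound 4 (beyond the scatter), upward and modest, held with low confidence.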

Compound 4, a percentage reported as activity, at one concentration (the size of the read-out at that concentration, not a potency): 18.1%
Beside the measured number, compound 4's estimate is 31.9 percentage points above it; the whole stated range lies above it.
By their numbers in this assay, from the lowest: compound 3; then compound 4; then compound 2; then compound 1.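

In this assay, the change from hydroxy to methoxy on the 3-chloro-5-hydroxyphenyl group gives a number 16.2 percentage points lower from compound 2 to compound 4 (beyond the scatter), so within this urea a free hydroxy is not required for the effect at the one concentration tested, and methylating that oxygen goes with a stronger effect. With methoxy held constant, placing (4-chloro-3-(trifluoromethyl)phenyl)amino in place of 3,4-dichlorophenyl on the carbonyl carbon gives a number 59.7 percentage points lower from compound 1 to compound 4 (beyond the scatter), so the methoxy group alone does not account for the weak effect of compound 1, and the change on the carbonyl carbon is a large one in this series. Nothing available explains why either step takes this direction or size.

The compounds shown leave open whether methylation has a similar effect with a 3,4-dichlorophenyl group on the urea, the setting in which compound 3 gives 0.57%. As far as these compounds go, it also remains open how the number would respond to an ethyl group or a 2-aminoethyl chain on the same oxygen, or to an amine in place of the hydroxy.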